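Aryl amide replacing the propenyl chain on the shared core

A few compounds are considered here, and "the series" means these few. Any claim that something is new, unique, unknown or untested is made for them only; others in the source may bear on it.

Going by the values given here, compound 1 `C/C=C/C(=O)Nc1c(C(O)(C(F)(F)F)C(F)(F)F)ccc2ccccc12` carries the prop-1-en-1-yl group on the carbonyl carbon; in an assay on LtK cells with ATP-sensitive inward rectifier potassium channel 11 (Homo sapiens) as the target (on this read-out higher numbers stand for an effect only at larger amounts of compound and lower numbers for an effect already at smaller amounts), compound 1 gives 72 nM, the highest of the three numbers so far. Compound 2 `O=C(Nc1c(C(O)(C(F)(F)F)C(F)(F)F)ccc2ccccc12)C1CCC1`, with cyclobutyl in that place, gives 45 nM in this assay; the step is a 1.6-fold lower number from compound 1 to compound 2 (0.20 log units; within the scatter). Compound 3 `Cc1cccc(C(=O)Nc2c(C(O)(C(F)(F)F)C(F)(F)F)ccc3ccccc23)c1`, with 3-methylphenyl, gives 23 nM in this assay; the step is a 3.1-fold lower number from compound 1 to compound 3 (0.50 log units; beyond the scatter), while between the two ring-bearing amides a 2.0-fold lower number from compound 2 to compound 3 (0.29 log units; within the scatter).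

Compound 4 `O=C(Nc1c(C(O)(C(F)(F)F)C(F)(F)F)ccc2ccccc12)c1cccc(C(F)(F)F)c1` has not been measured. It differs from compound 1 as follows: 3-(trifluoromethyl)phenyl in place of prop-1-en-1-yl on a carbonyl carbon. Compound 3 also carries an aromatic ring on the carbonyl carbon; its step of a 3.1-fold lower number from compound 1 to compound 3 (0.50 log units; beyond the scatter) bears most directly on compound 4. The step of a 1.6-fold lower number from compound 1 to compound 2 (0.20 log units; within the scatter) shows that a ring in this place on its own gives no step beyond the scatter. A step of about the size seen for compound 3, towards lower numbers, is therefore expected in this assay. For compound 4 the expected value is 25 nM, with a range from 10 nM to 60 nM. For compound 4 this amounts to an expected step of a 2.9-fold lower number from compound 1 to compound 4 (0.46 log units; beyond the scatter).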

Compound 4, half-maximal effective concentration: 84 nM
Compound 4: middle estimate off by 3.4-fold (0.53 log units), on the low side; measured number above the stated range.
By their numbers in this assay, from the lowest: compounds 3, 2, 1 and 4 (each within the scatter of the next, the first and the last beyond it).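

Notes on the aryl amides: in this assay, an aromatic ring on the carbonyl carbon does not alone go with the lower number, since trifluoromethyl in place of methyl on an aromatic carbon gives a 3.7-fold higher number from compound 3 to compound 4 (0.56 log units; beyond the scatter) and so the group carried by the ring also counts at this position. Compound 4 does not stand apart from the non-aromatic amides, with a 1.2-fold higher number from compound 1 to compound 4 (0.07 log units; within the scatter) and a 1.9-fold higher number from compound 2 to compound 4 (0.27 log units; within the scatter), so the separation seen for compound 3 from compound 1 does not extend to this second aryl amide. No measurement available here accounts for the difference between the methyl and trifluoromethyl groups.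

Still open, from the compounds shown here alone, is how phenyl, 3-chlorophenyl or 3-methoxyphenyl on the carbonyl carbon would read. Also open, going by these compounds, is whether a step of this size recurs for the same exchange on other amides of the shared core.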